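Dropping a Methyl Group from the Shared Core

This account rests on a few compounds, and the source may have more. Where it says the series, first, only, none or still open, it means among the compounds named here.

Measured so far:
compound 1, `Cc1ccc2[nH]c(=O)c(/C=N/Nc3ccc([N+](=O)[O-])cc3)cc2c1`, gives 350000 nM
compound 2, `O=c1[nH]c2ccccc2cc1/C=N/Nc1ccc([N+](=O)[O-])cc1`, gives 245000 nM
compound 3, `Cc1ccc2[nH]c(=O)c(/C=N/Cc3ccccc3)cc2c1`, gives 6920000 nM

All three values come from a functional assay, read by spectrophotometry, with a stated time of 1 h; on this read-out higher numbers stand for weaker inhibition and lower numbers for stronger inhibition. Compound 1 and compound 2 differ in one place, (hydrogen in place of methyl on an aromatic carbon), and this gave a 1.4-fold lower number from compound 1 to compound 2 (0.15 log units; within the scatter). Compound 3 shows the highest number of the three, so it is the weakest inhibitor here; the difference between its core and the core of compound 1 is not broken down here.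

Compound 4, `O=c1[nH]c2ccccc2cc1/C=N/Cc1ccccc1`, has not yet been measured. It differs from compound 3 by hydrogen in place of methyl on an aromatic carbon, the same change made from compound 1 to compound 2. Because that earlier step was a 1.4-fold lower number from compound 1 to compound 2 (0.15 log units; within the scatter), compound 4 is expected to move only a little, by an estimated 1.4-fold lower number from compound 3 to compound 4 (0.14 log units; within the scatter). In this assay compound 4 is estimated at 5000000 nM, likely between 2000000 nM and 12000000 nM.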

Compound 4, half-maximal inhibitory concentration: 3140000 nM
Estimate against measurement, compound 4: 1.6-fold (0.20 log units) above, and the stated range covers the measured number.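

Putting hydrogen in place of methyl on the aromatic carbon gives a 2.2-fold lower number from compound 3 to compound 4 (0.34 log units; beyond the scatter) in this assay, and this step agrees within the scatter with the same change on the other core: the same change on two cores in this assay, a 1.4-fold lower number (0.15 log units; within the scatter) from compound 1 to compound 2 and a 2.2-fold lower number (0.34 log units; beyond the scatter) from compound 3 to compound 4, 1.5-fold (0.19 log units) apart, within the scatter of two such steps. For the compounds shown here, the change thus behaves alike on these two cores, although only the step to compound 4 lies beyond the scatter on its own. Two pairs cannot show that the step would hold on any further core in the series, nor can they explain its size.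

From the compounds shown here alone, it remains open how other groups at this place, such as a chlorine atom, a methoxy group or an amine, would read. Also open, going by these compounds, is whether any of them would behave alike on both cores.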